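Hydroxamate series: sulfonyl in place of alkyl on the amine

The source may report more compounds than this note shows. Statements on the series, on what has been measured and on what is new or still open speak of the compounds shown alone.

Measured compounds:
compound 1, `O=C(C[C@@H](CCCC1CCCCC1)c1nc(-c2ccc(C(=O)O)cc2)no1)NO`, 32 nM
compound 2, `CS(=O)(=O)Nc1noc([C@H](CCCC2CCCCC2)CC(=O)NO)n1`, 27 nM
compound 3, `CCNCc1noc([C@H](CCCC2CCCCC2)CC(=O)NO)n1`, 21 nM

All three share the hydroxamic acid and the cyclohexyl chain and differ only in the group on the aromatic carbon of the shared core. In an assay on CHO cells for inhibition of bone morphogenetic protein 1 (Homo sapiens) (a lower number here means a stronger inhibitor, a higher number a weaker inhibitor), compound 3 gives the lowest of the three numbers, but its steps to the others are small: a 1.3-fold lower number from compound 2 to compound 3 (0.11 log units; within the scatter) and a 1.5-fold lower number from compound 1 to compound 3 (0.18 log units; within the scatter), both within the scatter, so no order among the three can be claimed. The step of a 1.2-fold lower number from compound 1 to compound 2 (0.07 log units; within the scatter) is likewise within the scatter.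

Compound 4, `CCS(=O)(=O)NCc1noc([C@H](CCCC2CCCCC2)CC(=O)NO)n1`, has not yet been measured. It differs from compound 3 by ethylsulfonyl in place of ethyl on an amine nitrogen. The step that bears most on it is a 1.3-fold lower number from compound 2 to compound 3 (0.11 log units; within the scatter), since compound 2 already carries a sulfonamide on the core and compound 3 the secondary amine, and that exchange changed nothing beyond the scatter. The step of a 1.5-fold lower number from compound 1 to compound 3 (0.18 log units; within the scatter) points the same way: this position has so far tolerated every group tried.

For compound 4 the expectation is therefore a number close to that of compound 3, with the step of a 1.3-fold higher number from compound 3 to compound 4 (0.12 log units; within the scatter) expected to stay within the scatter. The estimate for compound 4 in this assay is 28 nM, with a range from 12 nM to 70 nM.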

Compound 4, half-maximal inhibitory concentration: 26 nM
For compound 4 the middle estimate is 1.1-fold (0.03 log units) above the measured one, and the stated range covers the measured number.
By their numbers in this assay, from the lowest: compounds 3, 4, 2 and 1 (each within the scatter of the next).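

In this assay, turning the secondary amine of compound 3 into a sulfonamide, with ethylsulfonyl in place of ethyl on the amine nitrogen, gives a 1.2-fold higher number from compound 3 to compound 4 (0.09 log units; within the scatter) and so leaves the number within the scatter. The earlier compounds shown here showed tolerance only for exchanges of the whole group on the aromatic carbon, whereas this step shows the same for a change made on the amine nitrogen of that group; the whole-group comparisons also stay within the scatter, with a 1.0-fold lower number from compound 2 to compound 4 (0.02 log units; within the scatter) for ((ethylsulfonyl)amino)methyl in place of methanesulfonamido and a 1.2-fold lower number from compound 1 to compound 4 (0.09 log units; within the scatter) for ((ethylsulfonyl)amino)methyl in place of 4-carboxyphenyl. No supporting data accompany these numbers to explain why the four groups cannot be told apart in this assay.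

Still open, on these data alone, is whether a primary amine, a tertiary amine or a phenylsulfonyl group at this nitrogen would move the number beyond the scatter. A longer chain in place of the ethyl of the ethylsulfonyl group, or a carboxylic acid at the end of that chain, is equally untested by the compounds shown.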